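A Thioether in Place of an Ether on One Core

The source may report more compounds than this note shows. Statements on the series, on what has been measured and on what is new or still open speak of the compounds shown alone.

Measured so far:
compound 1, `Nc1cc(N)c2nc(-c3ccccc3)c(Oc3ccc(Cl)c(Cl)c3)nc2c1`, 28200 nM
compound 2, `COc1ccc(CNc2nc3cc(N)cc(N)c3nc2-c2ccccc2)cc1OC`, 12900 nM
compound 3, `COc1cc(CNc2nc3cc(N)cc(N)c3nc2-c2ccccc2)cc(OC)c1OC`, 3470 nM

In a functional assay on UACC-257 cells (Homo sapiens) for inhibition, read by sulforhodamine B assay, with a stated time of 48 h (on this read-out lower numbers stand for stronger inhibition of growth and higher numbers for weaker inhibition of growth), compound 1 gives the highest of the three numbers; compound 2 shows a lower value and compound 3 a lower one still. Within the data shown here, the only step between measured compounds that differ in one place, a 3.7-fold lower number from compound 2 to compound 3 (0.57 log units; beyond the scatter), concerns a methoxy group on another part of the molecule and does not bear on the change now considered. Compound 4, `Nc1cc(N)c2nc(-c3ccccc3)c(Sc3ccc(F)cc3)nc2c1`, differs from compound 1 by (4-fluorophenyl)sulfanyl in place of 3,4-dichlorophenoxy on an aromatic carbon. Among the measured compounds shown here, no measured pair tests this exchange, so the expected step in this assay is taken as none beyond the scatter, with wide uncertainty: a 1.1-fold lower number from compound 1 to compound 4 (0.05 log units; within the scatter). Compound 4 is therefore estimated at 25000 nM, between 8000 nM and 80000 nM.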

Compound 4, concentration for 50% growth inhibition: 16600 nM
Estimate against measurement, compound 4: 1.5-fold (0.18 log units) above; the measured number falls inside the stated range.
By their numbers in this assay, from the lowest: compound 3; then compounds 2, 4 and 1 (each within the scatter of the next, the first and the last beyond it).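

At this position on the shared core, this assay shows a 1.7-fold lower number from compound 1 to compound 4 (0.23 log units; within the scatter), so (4-fluorophenyl)sulfanyl and 3,4-dichlorophenoxy cannot be told apart here. The exchange alters both the atom linking the ring to the core and the halogens on that ring, so this single step does not separate the two changes. No evidence is available to explain the result. As far as these compounds go, what remains open is how each change acts alone, which 4-fluorophenoxy or 3,4-dichlorophenylsulfanyl on the same carbon could show.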